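Trifluoromethyl for methyl beside three compounds at a limit

The source may hold more compounds than are shown below. What is called first, only, known or untested is meant among the compounds shown, and "the series" means these compounds.

Three sulfonamides sharing one core have been tested in an assay on isolated protein for inhibition of malate dehydrogenase, mitochondrial (Sus scrofa), with stated times of 45 min and 30 min; a lower number here means a stronger inhibitor, a higher number a weaker inhibitor. Compound 1, `O=S(=O)(Nc1ccc(-c2nc3ccccc3o2)cc1)c1ccccc1Cl`, gives > 63000 nM, which is a limit of the assay rather than a measured number. Compound 2, `COc1ccccc1S(=O)(=O)Nc1ccc(-c2nc3ccccc3o2)cc1`, gives > 63000 nM, again a limit. Compound 3, `Cc1ccccc1S(=O)(=O)Nc1ccc(-c2nc3ccccc3o2)cc1`, gives > 63000 nM, also a limit. Because all three values sit at the limit of > 63000 nM in this assay, at which 3 of the 3 values shown sit, the steps between them cannot be read in size: a step that the two limits leave unreadable from compound 1 to compound 2, a step that the two limits leave unreadable from compound 1 to compound 3 and a step that the two limits leave unreadable from compound 2 to compound 3. Compound 3 therefore stands only at a limit, with no readable neighbour above or below it.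

Compound 4, `O=S(=O)(Nc1ccc(-c2nc3ccccc3o2)cc1)c1ccccc1C(F)(F)F`, differs from compound 3 by trifluoromethyl in place of methyl on an aromatic carbon. Within the data shown here, none of the measured steps bears on this change with a readable size, so the expectation rests on the limit shared by all three measured compounds. Compound 4 is expected to show a step that the limit leaves unreadable from compound 3 to compound 4, most likely remaining at a limit. Compound 4 is estimated at 100000 nM, with a range from 40000 nM to 300000 nM.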

Compound 4, half-maximal inhibitory concentration: > 63000 nM
Compound 4: no number, only a limit; the forecaster's own chance of this, stated with the estimate: 85%; the middle value lies beyond the limit too.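

Compound 4 gives > 63000 nM, which is a limit of the assay and not a number, so none of its steps from compound 1, compound 2 or compound 3 can be read in size: the limit of > 63000 nM in this assay, at which 4 of the 4 values shown sit. Going by these compounds, whether chloro, methoxy, methyl and trifluoromethyl differ in their effect on inhibition remains open.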